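Carbonyl substituent variation in a small furan-bearing series

The source may hold more compounds than are shown below. What is called first, only, known or untested is meant among the compounds shown, and "the series" means these compounds.

Measured in an assay on membranes from HeLa cells for displacement of a labelled ligand from adenosine receptor A3 (Homo sapiens), read by scintillation counting, with a stated time of 180 min, tested at 1 uM; a higher number here means more inhibition at the concentration tested (going by the name of the read-out), a lower number less inhibition:
compound 1 `CC1=C(C(N)=O)C(c2ccoc2)NC(=O)N1` gives 2%
compound 2 `CCSC(=O)C1=C(C)NC(=O)NC1c1ccoc1` gives 1%

Compound 2 and compound 1 lie within the scatter of each other, so the two numbers fix no order between them. Going by the values given here, the only measured step, a number 1 percentage points lower from compound 1 to compound 2 (within the scatter), concerns the same carbonyl carbon that is changed in compound 3 `CC1=C(C(=O)OC2CCC2)C(c2ccoc2)NC(=O)N1`, where (cyclobutyloxy in place of ethylsulfanyl on a carbonyl carbon). Among the compounds with values here, that step stayed within the scatter, and no other measured pair bears on the new substituent. The expected step is therefore a number 1 percentage points higher from compound 2 to compound 3 (within the scatter), within the scatter. The estimate for compound 3 is 2%, range 0% to 10%.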

Compound 3, a percentage reported as inhibition, at one concentration (the size of the read-out at that concentration, not a potency): 1%
Compound 3: middle estimate off by 1 percentage points, on the high side; the range from low to high includes it.
By their numbers in this assay, from the lowest: compounds 2, 3 and 1 (each within the scatter of the next).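

Cyclobutyloxy on the carbonyl carbon brings the first ring at this place, and this assay gives no change at the digits printed from compound 2 to compound 3 (within the scatter) and also a number 1 percentage points lower from compound 1 to compound 3 (within the scatter). At this concentration, the ring-bearing substituent therefore does not separate from ethylsulfanyl or amino. No evidence on hand bears on this result.

Still open, on these data alone, is whether a carboxylic acid, a benzylamine or a longer alkoxy chain on the same carbonyl carbon would give a reading beyond the scatter. With all three values this close, the series does not yet show whether this place affects the read-out.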